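The compounds below may be only part of what the source reports. "The series", "measured", "known", "first", "only" and "open" are said of these compounds alone.

Notes on the series.

Compound 2 `Nc1nc(-c2ccco2)nc2sc(CN3CC=CCC3)cc12` carries a six-membered non-aromatic ring with one hetero atom on a saturated chain carbon bound to an aromatic carbon; in an assay on CHO-K1 cells for antagonist activity at adenosine receptor A1 (Homo sapiens), read by a beta-galactosidase reporter, with stated times of 15 min and 6 h (a lower number here means a stronger inhibitor, a higher number a weaker inhibitor), compound 2 gives 150 nM. Compound 1 `Nc1nc(-c2ccco2)nc2sc(CN3CCCC3)cc12` differs by a group of 5 heavy atoms (4 carbon, 1 nitrogen; one five-membered non-aromatic ring with 1 hetero atom) in place of a group of 6 heavy atoms (5 carbon, 1 nitrogen; one six-membered non-aromatic ring with 1 hetero atom), on a saturated chain carbon bound to an aromatic carbon, and in this assay compound 1 gives 6430 nM; the step is a 43-fold higher number from compound 2 to compound 1 (1.63 log units; beyond the scatter). Compound 3 `N#Cc1cccc(-c2nc(N)c3cc(CN4CC=CCC4)sc3n2)c1` keeps the six-membered ring of compound 2 but its core differs by 3-cyanophenyl in place of furan-2-yl on an aromatic carbon; in this assay compound 3 gives 210 nM, and the step is a 1.4-fold higher number from compound 2 to compound 3 (0.15 log units; within the scatter).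

Compound 4 `N#Cc1cccc(-c2nc(N)c3cc(CN4CCCC4)sc3n2)c1` is not yet measured. It differs from compound 3 by a group of 5 heavy atoms (4 carbon, 1 nitrogen; one five-membered non-aromatic ring with 1 hetero atom) in place of a group of 6 heavy atoms (5 carbon, 1 nitrogen; one six-membered non-aromatic ring with 1 hetero atom), on a saturated chain carbon bound to an aromatic carbon, at the same place as in the pair of compound 2 and compound 1, so this is the same change, seen twice among these compounds. Among the compounds with values here, for compound 4 the step from compound 3 is expected to be a 38-fold higher number from compound 3 to compound 4 (1.58 log units; beyond the scatter), because a 43-fold higher number from compound 2 to compound 1 (1.63 log units; beyond the scatter) is the single precedent and is large and beyond the scatter, while the core difference between compound 2 and compound 3 gave only a 1.4-fold higher number from compound 2 to compound 3 (0.15 log units; within the scatter). Within the data shown here, compound 4 is therefore estimated at 8000 nM, with a range from 2500 nM to 30000 nM, the width reflecting that only one precedent exists.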

Compound 4, inhibition constant: 130 nM
Estimate against measurement, compound 4: 62-fold (1.79 log units) above, and the stated range ends above it.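

The replacement of the six-membered ring by pyrrolidin-1-yl does not carry from one core to the other in this assay: with 3-cyanophenyl on the core, the change gives a 1.6-fold lower number from compound 3 to compound 4 (0.21 log units; within the scatter), and the two steps differ: the same change on two cores in this assay, a 43-fold higher number (1.63 log units; beyond the scatter) from compound 2 to compound 1 and a 1.6-fold lower number (0.21 log units; within the scatter) from compound 3 to compound 4, 69-fold (1.84 log units) apart, beyond the scatter of two such steps. Read the other way, 3-cyanophenyl in place of furan-2-yl gives a 49-fold lower number from compound 1 to compound 4 (1.69 log units; beyond the scatter) with pyrrolidin-1-yl present, and this does not match the step seen with the six-membered ring: the same change on two cores in this assay, a 1.4-fold higher number (0.15 log units; within the scatter) from compound 2 to compound 3 and a 49-fold lower number (1.69 log units; beyond the scatter) from compound 1 to compound 4, 69-fold (1.84 log units) apart, beyond the scatter of two such steps. Within the data shown here, in these four compounds, a step measured on one core therefore does not predict the same change on the other, but this does not explain the difference or show how general it is, and the whole gap rests on the single value of compound 1, 6430 nM.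

The compounds shown leave open whether piperidine or morpholine on the saturated chain carbon would follow the furan-2-yl pair or the 3-cyanophenyl pair. On these data alone, it also remains open whether the gap is peculiar to furan-2-yl or also arises with an unsubstituted phenyl group on that aromatic carbon.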